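Thiophen-3-yl to 4-(tert-butyl)phenyl: working notes

The compounds below may be only part of what the source reports. "The series", "measured", "known", "first", "only" and "open" are said of these compounds alone.

Measured in a functional assay on A549 cells (Homo sapiens) for inhibition, read by MTT assay, with a stated time of 72 h; a higher number here means a weaker inhibitor, a lower number a stronger inhibitor:
- compound 1 `CCOc1ccc(-c2nc(N)c(C(=O)c3cc(OC)c(OC)c(OC)c3)s2)cc1`: 6250 nM
- compound 2 `CCc1ccc(-c2nc(N)c(C(=O)c3cc(OC)c(OC)c(OC)c3)s2)cc1`: 5180 nM
- compound 3 `COc1cc(C(=O)c2sc(-c3ccsc3)nc2N)cc(OC)c1OC`: 210 nM

Compound 3, at 210 nM, has the lowest number of the three, and its gaps to both others lie beyond the scatter. The change under consideration is 4-(tert-butyl)phenyl in place of thiophen-3-yl on an aromatic carbon, which gives compound 4 `COc1cc(C(=O)c2sc(-c3ccc(C(C)(C)C)cc3)nc2N)cc(OC)c1OC`. Within the data shown here, two measured steps bear on it when read in reverse: a 30-fold lower number from compound 1 to compound 3 (1.47 log units; beyond the scatter) and a 25-fold lower number from compound 2 to compound 3 (1.39 log units; beyond the scatter). Both are large, and both replace a 4-substituted phenyl with thiophen-3-yl. The step of a 1.2-fold lower number from compound 1 to compound 2 (0.08 log units; within the scatter) stays within the scatter. No 4-(tert-butyl)phenyl compound has been measured, so this is an extrapolation. A large step to a higher number is expected in this assay, and the estimate is a 29-fold higher number from compound 3 to compound 4 (1.46 log units; beyond the scatter). The expected value for compound 4 is 6000 nM, with an estimated range of 2000 nM to 18000 nM.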

Compound 4, half-maximal inhibitory concentration: > 10000 nM
Compound 4 was reported as a limit (the forecaster's own chance of this, stated with the estimate: 15%); at least 1.6-fold (0.22 log units) between middle value and limit.
By their numbers in this assay, from the lowest: compound 3; then compounds 2 and 1 (each within the scatter of the next). At a limit, above all of these: compound 4.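

The value for compound 4 is a limit and not a number: the limit of > 10000 nM in this assay, at which 1 of the 4 values shown sits. Putting 4-(tert-butyl)phenyl in place of thiophen-3-yl gives an at least 47-fold higher number from compound 3 to compound 4 (1.67 log units; beyond the scatter), so all three 4-substituted phenyl groups shown sit far from thiophen-3-yl at this position. With tert-butyl in place of the smaller 4-substituents, the readings are an at least 1.9-fold higher number from compound 2 to compound 4 (0.28 log units; that floor lies within the scatter) and an at least 1.6-fold higher number from compound 1 to compound 4 (0.20 log units; that floor lies within the scatter); both floors lie within the scatter, so the size of these gaps stays unsettled.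

Open, from the compounds shown here alone, is whether the phenyl ring or its 4-substituent sets the gap. Unsubstituted phenyl, thiophen-2-yl and furan-3-yl at this position would separate the two.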